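Swapping the amine-bearing side chain on a shared core

This account rests on a few compounds, and the source may have more. Where it says the series, first, only, none or still open, it means among the compounds named here.

Among the measured compounds shown here, compound 1 `CN1CCC(Oc2ccc(-c3nc4ccc(Oc5ccc(Cl)cc5)cc4o3)cc2)CC1` is the only member of this small set with a measured number: in an assay on isolated protein for inhibition of advanced glycosylation end product-specific receptor (Homo sapiens), read by FRET, with stated times of 30 min and 1 h, tested at 4 uM (a higher number here means more inhibition at the concentration tested (going by the name of the read-out), a lower number less inhibition), compound 1 gives 19.5%, a modest effect at the single concentration tested. Compound 2 `Clc1ccc(Oc2ccc3nc(-c4ccc(OCCCN5CCCC5)cc4)oc3c2)cc1` carries the same core with a different amine-bearing chain on the aromatic oxygen; in this assay compound 2 gives "not active" (no number reported), without a number. Compound 3 `Clc1ccc(Oc2ccc3nc(-c4ccc(OCCCN5CCCCC5)cc4)oc3c2)cc1` has not yet been measured. It differs from compound 1 in one place: 3-(piperidin-1-yl)propyl in place of 1-methylpiperidin-4-yl on an oxygen on an aromatic ring. Compound 3 thus resembles compound 2 far more than compound 1 in the part that changes. For the measured compounds named here, no measured pair here shows how such a change moves the read-out, so the expectation rests on the two measured compounds alone. The step from compound 1 to compound 3 in this assay is expected to be a drop, a number 11.5 percentage points lower from compound 1 to compound 3 (beyond the scatter), beyond the usual scatter. Compound 3 is therefore estimated to give 8%, within a range from 0% to 22%, with a real chance that only a limit and no number is reported.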

Compound 3, a percentage reported as inhibition, at one concentration (the size of the read-out at that concentration, not a potency): 2.2%
Compound 3: the middle estimate sits 5.8 percentage points above what was measured; the range from low to high includes it.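

In this assay, among the compounds shown here, putting 3-(piperidin-1-yl)propyl in place of 1-methylpiperidin-4-yl on an oxygen on an aromatic ring gives a number 17.3 percentage points lower from compound 1 to compound 3 (beyond the scatter) and so provides the first measured step at this position. The read-out therefore responds to this change even though a six-membered non-aromatic ring stays in the side chain and only the way it is joined to the oxygen differs. No measurement shown here explains the drop.

On these data alone, it remains open whether the propyl link or the changed attachment to the ring matters more, and each value comes from a single tested concentration. A shorter 2-(piperidin-1-yl)ethyl chain, a longer 4-(piperidin-1-yl)butyl chain or a morpholine ring on the same oxygen could help to separate these effects.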